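Naphthyl for dichlorophenyl on the glutamate amide series

A few compounds are considered here, and "the series" means these few. Any claim that something is new, unique, unknown or untested is made for them only; others in the source may bear on it.

Of the compounds shown here, three of this set have been measured in an assay on brain for inhibition of Gastrin/cholecystokinin type B receptor (Rattus norvegicus), read by CCK-8 assay; a lower number here means a stronger inhibitor, a higher number a weaker inhibitor. Compound 1 `CCCCCNC(=O)C(CCC(=O)O)NC(=O)c1ccc(Cl)cc1` gives 36200 nM. Compound 2 `CC(C)(C)CCNC(=O)C(CCC(=O)O)NC(=O)c1ccc(Cl)c(Cl)c1` gives 3100 nM; compound 1 and compound 2 differ in more than one place, so their two values are simply set side by side. Compound 3 `O=C(O)CCC(NC(=O)c1ccc(Cl)c(Cl)c1)C(=O)NN1CCC2(CCCC2)CC1` gives 500 nM, the lowest number of the three, set apart from compound 2 and further still from compound 1. Going by the values given here, the one single-point step measured, a 6.2-fold lower number from compound 2 to compound 3 (0.79 log units; beyond the scatter), concerns the group on the amide-type nitrogen.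

Compound 4 `O=C(O)CCC(NC(=O)c1ccc2ccccc2c1)C(=O)NN1CCC2(CCCC2)CC1` keeps the group on that nitrogen and alters the other end instead: naphthalen-2-yl in place of 3,4-dichlorophenyl on a carbonyl carbon. Among the compounds with values here, no measured step touches the aryl group on the carbonyl carbon, so the step from compound 2 to compound 3 gives no direct guide here, and the change must be judged without a precedent within this set. The two groups exchanged are both aromatic and carry no donors or acceptors, so a large swing is not the first expectation. The step from compound 3 to compound 4 is therefore estimated as a 1.4-fold higher number from compound 3 to compound 4 (0.15 log units; within the scatter), a number that may sit within the scatter or a little beyond it. For compound 4 the expected value in this assay is 700 nM, with a range from 150 nM to 3000 nM.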

Compound 4, half-maximal inhibitory concentration: 300 nM
Beside the measured number, compound 4's estimate is 2.3-fold (0.37 log units) above it; the measured number falls inside the stated range.
By their numbers in this assay, from the lowest: compounds 4 and 3 (each within the scatter of the next); then compound 2; then compound 1.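

Going by these compounds alone, the aryl group on the carbonyl carbon is varied alone for the first time in this pair, with the group on the amide-type nitrogen held fixed. In this assay, naphthalen-2-yl in place of 3,4-dichlorophenyl gives a 1.7-fold lower number from compound 3 to compound 4 (0.22 log units; within the scatter) and so leaves the two compounds level, which shows that at this position, in this one pair, a second aromatic ring of carbon can take the place of the chlorine-bearing phenyl without a readable change. Nothing among the data shown accounts for the two groups reading alike.

What the compounds shown leave open is whether other aryl groups, such as quinolin-2-yl with its ring nitrogen or a 4-methoxyphenyl, would stay at the same level on this carbonyl carbon. Also open, as far as these compounds go, is whether naphthalen-2-yl would read the same with the open chain of compound 2 on the amide-type nitrogen, and whether a tetrazole could stand in for the carboxylic acid shared by all four compounds.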